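Oxazole amide series: aryl change on the piperazine nitrogen

The compounds below may be only part of what the source reports. "The series", "measured", "known", "first", "only" and "open" are said of these compounds alone.

Measured so far:
- compound 1, `Cc1nc(-c2ccccc2)c(C(=O)N2CCN(c3cccc(C(N)=O)c3)CC2)o1`: 71 nM
- compound 2, `CCc1nc(-c2ccc(F)cc2)c(C(=O)N2CCN(c3cccc(OC)c3)CC2)o1`: 411 nM

Two compounds have numbers in a functional assay on HL-60 cells (Homo sapiens) for inhibition, read by MTT assay, with a stated time of 72 h; a lower number here means a stronger inhibitor, a higher number a weaker inhibitor. Compound 1 stands lowest of the two; compound 2 gives the higher number, and the gap between them lies beyond the usual scatter. Compound 2 differs from compound 1 in more than one place, so no single step can be read from that pair.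

Compound 3, `Cc1nc(-c2ccccc2)c(C(=O)N2CCN(c3ccc(Cl)c(Cl)c3)CC2)o1`, has not yet been measured. It shares the core of compound 1 and differs from it in one place: 3,4-dichlorophenyl in place of 3-carbamoylphenyl on an amine nitrogen in a ring. The change removes the only hydrogen-bond donor and acceptor of the group that leaves, while keeping a six-membered aromatic ring of carbon only at the same position.

Going by the values given here, no measured pair isolates this change, so the expectation rests on compound 1 alone. The step expected from compound 1 to compound 3 in this assay is a 2.3-fold higher number from compound 1 to compound 3 (0.35 log units; beyond the scatter), a modest move toward a higher number, which may or may not exceed the scatter. Compound 3 is thus estimated at 160 nM, with a range from 45 nM to 600 nM.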

Compound 3, half-maximal inhibitory concentration: 124 nM
Compound 3: middle estimate off by 1.3-fold (0.11 log units), on the high side; low and high end bracket the measured number.
By their numbers in this assay, from the lowest: compounds 1 and 3 (each within the scatter of the next); then compound 2.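

Going by these compounds alone, on the amine nitrogen in the six-membered non-aromatic ring with 2 nitrogen, placing 3,4-dichlorophenyl in place of 3-carbamoylphenyl gives in this assay a 1.7-fold higher number from compound 1 to compound 3 (0.24 log units; within the scatter) and is the only single-place comparison available at this position. On the core of compound 1, the hydrogen-bond donor and acceptor counted on 3-carbamoylphenyl are thus not needed for a number within the scatter of compound 1, as 3,4-dichlorophenyl carries neither and the two compounds cannot be separated in this assay on this pair alone. No separate measurement bears on why these two different aryl groups give numbers so close together.

Open, on these data alone, is whether this tolerance extends beyond these two groups, for instance to an unsubstituted phenyl or to a phenyl carrying a carboxylic acid or an amine at the same place on the core of compound 1. The steps involving compound 2 cannot be read, since it differs from both other compounds in more than one place, which leaves the contribution of its 3-methoxyphenyl group unresolved.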